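The source may report more compounds than this note shows. Statements on the series, on what has been measured and on what is new or still open speak of the compounds shown alone.

In a functional assay on the whole organism (strain Kunming) for inhibition, with Mus musculus as the target, with a stated time of 1 h, at a dose of 40 mg/kg by the oral route (a lower number here means less inhibition, a higher number more inhibition at the dose given (going by the name of the read-out)), compound 3 `O=C(/C=C/c1ccccc1)c1ccc(N2CCN(c3cccc(Cl)c3Cl)CC2)cc1` gives 30.7%, the second highest of the three measured numbers. Compound 1 `O=C(/C=C/c1ccccc1)c1ccc(N2CCN(c3ccc(Cl)c(Cl)c3)CC2)cc1` gives 13.4% and compound 2 `O=C(/C=C/c1ccccc1)c1ccc(N2CCN(c3ccc([N+](=O)[O-])cc3)CC2)cc1` gives 55.4%. The two steps that reach the middle compound are a number 17.3 percentage points higher from compound 1 to compound 3 (beyond the scatter) and a number 24.7 percentage points lower from compound 2 to compound 3 (beyond the scatter), both beyond the scatter. Compound 4 `O=C(/C=C/c1ccccc1)c1ccc(N2CCN(c3ccccc3Cl)CC2)cc1` differs from compound 3 by hydrogen in place of chloro on an aromatic carbon. Among the compounds with values here, none of the measured steps removes a chloro group outright: a number 42 percentage points higher from compound 1 to compound 2 (beyond the scatter) exchanges a dichlorophenyl for a nitrophenyl, and a number 17.3 percentage points higher from compound 1 to compound 3 (beyond the scatter) exchanges 3,4-dichlorophenyl for 2,3-dichlorophenyl while keeping both chloro groups. They show that altering the group on the amine nitrogen in the ring can shift the number by a modest to large amount, but they do not point to a direction for losing one chloro. The step expected here is a number 5.7 percentage points lower from compound 3 to compound 4 (within the scatter), with little confidence in its sign. Compound 4 is therefore expected to give about 25%, within an estimated range from 8% to 45%.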

Compound 4, a percentage reported as inhibition, in the whole organism at one dose (the size of the read-out at that dose, not a potency): 4.71%
Beside the measured number, compound 4's estimate is 20.3 percentage points above it; the whole stated range lies above it.
By their numbers in this assay, from the lowest: compounds 4 and 1 (each within the scatter of the next); then compound 3; then compound 2.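

Going from 2,3-dichlorophenyl to 2-chlorophenyl gives a number 26 percentage points lower from compound 3 to compound 4 (beyond the scatter) in this assay and is the first measured step that removes a chloro group outright, so this chloro group matters for the read-out in this series. The new compound also sits far from the 4-nitrophenyl compound, with a number 50.7 percentage points lower from compound 2 to compound 4 (beyond the scatter) on the nitrogen of the ring, whereas the comparison with 3,4-dichlorophenyl gives a number 8.7 percentage points lower from compound 1 to compound 4 (within the scatter) and does not separate those two groups. Nothing measured here bears on why the chloro group matters.

Still open, from the compounds shown here alone, is whether a methyl, a methoxy group or an amine in place of this chloro group would keep the number of compound 3 or lose it as hydrogen does. Also open, going by these compounds, is what replacing the other chloro group of compound 3 with hydrogen would do.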